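The source may hold more compounds than are shown below. What is called first, only, known or untested is meant among the compounds shown, and "the series" means these compounds.

Of the compounds shown here, three sharing one core have been tested in a functional assay on BGC-823 cells (Homo sapiens) for antiproliferative activity, read by MTT assay, tested at 5 uM; on this read-out lower numbers stand for a weaker effect and higher numbers for a stronger effect at the one concentration tested. Compound 1, `COc1cc(C2=NN(C(C)=O)C(c3cccc(F)c3)O2)cc(OC)c1OC`, gives 37.7%. Compound 2, `COc1cc(C2=NN(C(C)=O)C(c3ccccc3C(F)(F)F)O2)cc(OC)c1OC`, gives 34.8%, and the step of a number 2.9 percentage points lower from compound 1 to compound 2 (within the scatter) is only a small shift. Compound 3, `COc1cc(C2=NN(C(C)=O)C(c3ccc(F)c(F)c3)O2)cc(OC)c1OC`, gives 21.6%, the lowest of the three numbers; the drops a number 16.1 percentage points lower from compound 1 to compound 3 (beyond the scatter) and a number 13.2 percentage points lower from compound 2 to compound 3 (beyond the scatter) both go beyond the scatter.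

Compound 4, `COc1cc(C2=NN(C(C)=O)C(c3ccc(F)cc3)O2)cc(OC)c1OC`, differs from compound 3 in one place: hydrogen in place of fluoro on an aromatic carbon. The step from compound 1 to compound 3 is the one that bears on this, since it added a fluoro group to an aromatic carbon and the number fell by a modest amount. Compound 4 undoes one fluoro group, though the ring that results, 4-fluorophenyl, is not the 3-fluorophenyl of compound 1, so a full return to the level of compound 1 cannot be assumed. A modest rise in this assay, a number 9.4 percentage points higher from compound 3 to compound 4 (within the scatter), is therefore expected. Compound 4 is estimated at 31%, with a range from 19% to 43%.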

Compound 4, a percentage reported as inhibition, at one concentration (the size of the read-out at that concentration, not a potency): 13.3%
Estimate against measurement, compound 4: 17.7 percentage points above, and the stated range ends above it.
By their numbers in this assay, from the lowest: compounds 4 and 3 (each within the scatter of the next); then compounds 2 and 1 (each within the scatter of the next).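

Removing one fluoro from the 3,4-difluorophenyl ring brings no recovery: the step of a number 8.3 percentage points lower from compound 3 to compound 4 (within the scatter) leaves compound 3 and compound 4 indistinguishable in this assay, so this hydrogen-for-fluoro change has no readable effect here. The larger contrast lies between two rings that each carry a single fluoro, since the step of a number 24.4 percentage points lower from compound 1 to compound 4 (beyond the scatter) separates the 3-fluorophenyl and 4-fluorophenyl rings by more than the scatter. The step of a number 21.5 percentage points lower from compound 2 to compound 4 (beyond the scatter) likewise places the 4-fluorophenyl ring clearly apart from the 2-(trifluoromethyl)phenyl ring, so among these four compounds the fluoro's place on the ring matters more than the removal of a second fluoro.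

Still open, from the compounds shown here alone, is how this ring would read with an amine or a carboxylic acid in place of fluoro, and nothing at hand explains the differences seen.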